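A few compounds are considered here, and "the series" means these few. Any claim that something is new, unique, unknown or untested is made for them only; others in the source may bear on it.

Compound 3 `CCOC(=O)c1cnn(-c2nc(-c3ccc(OC)cc3)c(C#N)c(=O)n2C)c1N` gives 68 ug/mL in a functional assay on microsomes for inhibition, with a stated time of 1 h (a lower number here means a stronger inhibitor, a higher number a weaker inhibitor), the lowest of the three numbers shown, though its gaps to compound 2 `CCOC(=O)c1cnn(-c2nc(-c3ccc(Cl)cc3)c(C#N)c(=O)n2C)c1N` with 88 ug/mL and to compound 1 `CCOC(=O)c1cnn(-c2nc(-c3ccccc3Cl)c(C#N)c(=O)n2C)c1N` with 102 ug/mL both lie within the scatter. Compound 4 `CCOC(=O)c1cnn(-c2nc(-c3cccs3)c(C#N)c(=O)n2C)c1N` differs from compound 3 by thiophen-2-yl in place of 4-methoxyphenyl on an aromatic carbon. Every measured step changes only the aromatic group at this position: a 1.2-fold lower number from compound 1 to compound 2 (0.06 log units; within the scatter), a 1.5-fold lower number from compound 1 to compound 3 (0.18 log units; within the scatter) and a 1.3-fold lower number from compound 2 to compound 3 (0.11 log units; within the scatter), none of them beyond the scatter. For the measured compounds named here, no measured step swaps the six-membered ring for a five-membered one, so these steps bear on the change only loosely, and no step beyond the scatter is expected in this assay. Compound 4 is therefore estimated at 70 ug/mL, with a range from 35 ug/mL to 140 ug/mL, meaning an expected step of a 1.0-fold higher number from compound 3 to compound 4 (0.01 log units; within the scatter).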

Compound 4, half-maximal inhibitory concentration: 97 ug/mL
The estimate for compound 4 lay 1.4-fold (0.14 log units) below the measured number; the measured number falls inside the stated range.
By their numbers in this assay, from the lowest: compounds 3, 2, 4 and 1 (each within the scatter of the next).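

In this assay the swap to thiophen-2-yl gives a 1.4-fold higher number from compound 3 to compound 4 (0.15 log units; within the scatter) while the swaps from the two chlorophenyl groups give a 1.1-fold higher number from compound 2 to compound 4 (0.04 log units; within the scatter) and a 1.1-fold lower number from compound 1 to compound 4 (0.02 log units; within the scatter) and thus all three steps stay within the scatter. This position therefore takes a five-membered aromatic ring with 1 hetero atom and fewer heavy atoms than 4-methoxyphenyl without a step beyond the scatter, which the six-membered rings alone could not show. Nothing measured gives a reason for this. 

All groups shown at this position are aromatic rings, so whether an amine, a carboxylic acid or a longer chain there would give a step beyond the scatter stays open.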